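A few compounds are considered here, and "the series" means these few. Any claim that something is new, unique, unknown or untested is made for them only; others in the source may bear on it.

Measured compounds:
- compound 1, `O=C(/C=C\Nc1ccc(F)cc1)c1cn(-c2ccccc2)nc1-c1ccccc1`: 7980 nM
- compound 2, `COc1cc(N/C=C\C(=O)c2cn(-c3ccccc3)nc2-c2ccccc2)cc(OC)c1OC`: 5930 nM
- compound 3, `O=C(/C=C\Nc1ccc(F)cc1)c1cn(-c2ccccc2)nc1-c1ccc(F)cc1`: 7900 nM

All three values come from a functional assay on PC-3 cells (Homo sapiens) for antiproliferative activity, read by MTT assay, with a stated time of 48 h; a higher number here means a weaker inhibitor, a lower number a stronger inhibitor. Going by the values given here, the one single-point change already measured runs from compound 1 to compound 3: fluoro in place of hydrogen on an aromatic carbon. This change gave a 1.0-fold lower number from compound 1 to compound 3 (0.00 log units; within the scatter), so in this assay the two compounds are not distinguishable. Compound 2 shares the enone and pyrazole part with compound 1 but carries a different aniline; the difference between the two cores is not broken down here. Its value lies close to those of compound 1 and compound 3, and no order among the three can be read from these numbers.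

Compound 4, `COc1cc(N/C=C\C(=O)c2cn(-c3ccccc3)nc2-c2ccc(F)cc2)cc(OC)c1OC`, has not been measured. It stands to compound 2 as compound 3 stands to compound 1: fluoro in place of hydrogen on an aromatic carbon. The place of the change is described in the same words for both pairs, so this is the same change, made on the core of compound 2 instead of the core of compound 1.

In this assay, among the compounds with values here, the expected step from compound 2 to compound 4 is a 1.0-fold lower number from compound 2 to compound 4 (0.00 log units; within the scatter), resting on the single precedent that the step from compound 1 to compound 3 was a 1.0-fold lower number from compound 1 to compound 3 (0.00 log units; within the scatter). Within the data shown here, with only one precedent, the expectation carries the full scatter of the assay and no more. Compound 4 is therefore estimated at 5900 nM, with a range from 3000 nM to 12000 nM.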

Compound 4, half-maximal inhibitory concentration: 4890 nM
Compound 4: the middle estimate sits 1.2-fold (0.08 log units) above what was measured; low and high end bracket the measured number.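

In this assay, phenyl to 4-fluorophenyl gives a 1.2-fold lower number from compound 2 to compound 4 (0.08 log units; within the scatter). Set beside the earlier step, the change reads the same on both cores: the same change on two cores in this assay, a 1.0-fold lower number (0.00 log units; within the scatter) from compound 1 to compound 3 and a 1.2-fold lower number (0.08 log units; within the scatter) from compound 2 to compound 4, 1.2-fold (0.08 log units) apart, within the scatter of two such steps. Going by these compounds alone, this shows only that the change leaves the number within the scatter on two cores that differ in their aniline, so the earlier result carries over here; it does not show that the change is without effect elsewhere, since two pairs are a small base and agreement between two steps this small says nothing about whether a larger step would carry from core to core in the same way.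

The compounds shown leave open whether another group at this place on the ring, such as chloro, methoxy, an amine or a carboxylic acid, would give a step beyond the scatter, and whether such a step would be the same size on the core of compound 1 and the core of compound 2. They also leave open how the series would read with an aniline carrying a longer chain or a basic amine in place of the substituents present in these compounds.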